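A few compounds are considered here, and "the series" means these few. Any claim that something is new, unique, unknown or untested is made for them only; others in the source may bear on it.

Measured so far in a functional assay on MCF7 cells (Homo sapiens) for cytotoxicity, read by MTT assay, with a stated time of 48 h (a lower number here means a stronger inhibitor, a higher number a weaker inhibitor), are two compounds:
- compound 1 `Cc1n[nH]c2c1C(c1ccc(N(C)C)cc1)C(C(=O)n1ncc(C#N)c1N)=C(N)N2` gives 62700 nM in this assay
- compound 2 `Cc1n[nH]c2c1C(c1ccc(N(C)C)cc1)C(C(=O)N/N=C1/C(=O)Nc3ccccc31)=C(N)N2` gives 59100 nM in this assay

Going by the values given here, compound 2 stands within the scatter of compound 1, so the two numbers set no order within this pair. Compound 3 `Cc1n[nH]c2c1C(c1ccc(N(C)C)cc1)C(C(N)=O)=C(N)N2` has no value yet. Going from compound 2 to compound 3, the change is a hydrogen atom in place of a group of 11 heavy atoms (8 carbon, 2 nitrogen, 1 oxygen; one five-membered non-aromatic ring with 1 hetero atom, one six-membered aromatic ring of carbon only), on an amide-type nitrogen and it puts a hydrogen atom on an amide-type nitrogen in place of a group of 11 heavy atoms, which takes away one five-membered non-aromatic ring with 1 hetero atom and one six-membered aromatic ring of carbon only.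

Among the compounds with values here, no measured pair isolates a single change, so this step has no direct precedent in this assay and the uncertainty stays wide. The expectation rests only on compound 1 at 62700 nM and compound 2 at 59100 nM as the values nearest to hand. No change beyond the scatter is expected, and the estimated step is a 1.3-fold lower number from compound 2 to compound 3 (0.12 log units; within the scatter) in size. For compound 3 the estimated value is 45000 nM with an expected range from 15000 nM to 110000 nM in this assay.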

Compound 3, half-maximal inhibitory concentration: 4550 nM
Compound 3: middle estimate off by 9.9-fold (1.00 log units), on the high side; the measured number lies below the stated range.
By their numbers in this assay, from the lowest: compound 3; then compounds 2 and 1 (each within the scatter of the next).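

In this assay, the group on the carbonyl carbon now shows a clear effect on the read-out, where compound 1 and compound 2 alone gave no separation: the record shows a 13-fold lower number from compound 2 to compound 3 (1.11 log units; beyond the scatter) for a hydrogen atom in place of the group of 11 heavy atoms on the amide-type nitrogen. With amino in place of 5-amino-4-cyano-1H-pyrazol-1-yl on the carbonyl carbon, it shows a 14-fold lower number from compound 1 to compound 3 (1.14 log units; beyond the scatter) of similar size, so both larger groups, different as they are, sit on the weaker side of the plain amino group in these three compounds. Nothing on hand accounts for these steps, so they stand as observations only.

From the compounds shown here alone, whether the plain amino group itself is needed, or whether a small replacement on the carbonyl carbon such as methylamino, or a hydroxyl giving the carboxylic acid, would hold the lower number, remains open. Also open, going by these compounds, is whether the same steps would appear on a core carrying methoxy in place of the dimethylamino group.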